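From Cyclopentyl to 2-Hydroxyethyl on the Amide Nitrogen

This account rests on a few compounds, and the source may have more. Where it says the series, first, only, none or still open, it means among the compounds named here.

Of the compounds shown here, two have been measured in an assay on HEK293 cells for displacement of a labelled ligand from adenosine receptor A2b (Homo sapiens), read by scintillation counting, with a stated time of 30 min, tested at 10 uM; a higher number here means more inhibition at the concentration tested (going by the name of the read-out), a lower number less inhibition. Compound 1, `COc1cccc2cc(C(=O)NC3CCCC3)c(=N)oc12`, carries a cyclopentyl group on its amide nitrogen, and in this assay compound 1 gives 47%. Compound 2, `O=C(NCC(O)CO)c1cc2cccc(O)c2oc1=O`, differs from compound 1 in more than one place, so only its number can be set beside that of compound 1: in this assay compound 2 gives 29%. Compound 1 thus stands highest of the two numbers, and the gap to compound 2 lies beyond the usual scatter.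

The next compound, compound 3, `COc1cccc2cc(C(=O)NCCO)c(=N)oc12`, keeps the core of compound 1 and changes only the amide substituent: 2-hydroxyethyl in place of cyclopentyl on an amide-type nitrogen.

Among the measured compounds shown here, no step between measured compounds that differ in one place is available to calibrate this change. Compound 3 is expected to fall below compound 1 by a number 17 percentage points lower from compound 1 to compound 3 (beyond the scatter), a drop beyond the scatter. This expectation leans on compound 2, which gives 29%. Compound 3 is therefore estimated at 30%, within a range of 10% to 50%.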

Compound 3, a percentage reported as inhibition, at one concentration (the size of the read-out at that concentration, not a potency): 65%
The estimate for compound 3 lay 35 percentage points below the measured number; the measured number lies above the stated range.
By their numbers in this assay, from the lowest: compound 2; then compound 1; then compound 3.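

In this assay, the step from cyclopentyl to 2-hydroxyethyl on the amide-type nitrogen, with the core of compound 1 unchanged, gives a number 18 percentage points higher from compound 1 to compound 3 (beyond the scatter). Among the compounds shown here, this is the first change at this position that can be read on its own, and it shows that this amide-type nitrogen does not need the five-membered carbon ring to give inhibition at the concentration tested: an open chain of 2 carbons and 1 oxygen, with 1 hydrogen-bond donor and 1 hydrogen-bond acceptor where cyclopentyl has neither, gives the higher number. No measurement at hand accounts for the direction or the size of this step.

The loss of the ring, the shorter substituent and the arrival of the hydroxyl group all come together in this single step, and the compounds shown do not separate them. On the same core, a plain ethyl group would speak to the role of the oxygen, while a 2-methoxyethyl group, a 3-hydroxypropyl chain or a 2-aminoethyl group would show how far this position accepts other changes to the chain.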